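Swapping a benzoyl for a phenyl beside the ring sulfur

The source may hold more compounds than are shown below. What is called first, only, known or untested is meant among the compounds shown, and "the series" means these compounds.

Of the compounds shown here, two sharing one core have been tested so far. Compound 1, `CCOC(=O)C1CCN(C(=O)c2cc3sccc3n2Cc2ccc(OC)cc2)CC1`, is the smaller of the two. In an ADME assay on HEK-293T cells (Homo sapiens) for cytotoxicity, read by luminescence, with a stated time of 24 h (on this read-out higher numbers stand for lower toxicity in this test and lower numbers for higher toxicity in this test), compound 1 gives 39000 nM. Compound 2, `CCCNC(=O)C1CCN(C(=O)c2cc3sc(C(=O)c4ccccc4)cc3n2Cc2ccc(OC)cc2)CC1`, carries a benzoyl group on the thiophene part of the core and a propylamide instead of the ethyl ester. In this assay compound 2 gives > 100000 nM, and this is a limit of the assay. Compound 2 therefore stands at the limit of > 100000 nM in this assay, at which 1 of the 2 values shown sits, so only its floor is known, not its exact value.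

Compound 3, `CCCNC(=O)C1CCN(C(=O)c2cc3sc(-c4ccccc4)cc3n2Cc2ccc(OC)cc2)CC1`, differs from compound 2 in one place: phenyl in place of benzoyl on an aromatic carbon, next to the ring sulfur. Among the compounds with values here, no measured pair in this set shows what such a swap does to the read-out, so no direction can be taken from the data. Compound 3 is expected to remain weakly toxic, with an estimated value of 80000 nM, in a range from 20000 nM to 300000 nM. The step this estimate implies, an at least 1.2-fold lower number from compound 2 to compound 3 (0.09 log units; that floor lies within the scatter), is expected to lie within the usual scatter, with a real chance that the assay again reports only a limit.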

Compound 3, half-maximal cytotoxic concentration: > 100000 nM
Compound 3 gave a limit, no number; the forecaster's own chance of this, stated with the estimate: 55%; middle value at least 1.2-fold (0.09 log units) from the limit.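

Compound 2 and compound 3 both end at a limit in this assay and not at a number, so no step can be read for the swap of benzoyl to phenyl: the limit of > 100000 nM in this assay, at which 2 of the 3 values shown sit. The compounds shown leave open how far either compound lies from that limit, and so whether this swap changes the read-out at all.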